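From 2-Fluorophenyl to 4-Fluorophenyl in Compound 3

A few compounds are considered here, and "the series" means these few. Any claim that something is new, unique, unknown or untested is made for them only; others in the source may bear on it.

In a functional assay on MKN-45 cells (Homo sapiens) for inhibition, read by CCK-8 assay, with a stated time of 24 h (a higher number here means a weaker inhibitor, a lower number a stronger inhibitor), compound 1 `O=C1Nc2ccccc2/C1=C/c1ccc(-c2cn(-c3ccc(F)cc3)nn2)cc1` gives 16700 nM, and compound 2 `O=C1Nc2ccc(F)cc2/C1=C/c1ccc(-c2cn(-c3ccccc3F)nn2)cc1` gives 8510 nM. Compound 2 therefore stands within the usual scatter of compound 1, and the two numbers cannot be told apart. Among the compounds with values here, these two compounds differ in more than one place, so no single-place step has yet been measured. Compound 3 `O=C1Nc2ccc(F)cc2/C1=C/c1ccc(-c2cn(-c3ccc(F)cc3)nn2)cc1` follows from compound 2 through one change, 4-fluorophenyl in place of 2-fluorophenyl on an aromatic nitrogen. The 4-fluorophenyl group also occurs in compound 1, at 16700 nM, while the rest of the structure matches compound 2, at 8510 nM. On that basis, no step beyond the scatter is expected in this assay. The estimated change is a 1.3-fold higher number from compound 2 to compound 3 (0.11 log units; within the scatter). For compound 3 the expected value is 11000 nM, with an estimated range of 4500 nM to 27000 nM.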

Compound 3, half-maximal inhibitory concentration: > 20000 nM
Compound 3: a limit, no number (the forecaster's own chance of this, stated with the estimate: 5%); middle value at least 1.8-fold (0.25 log units) from the limit.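

Compound 3 gives a limit of the assay and not a number: the limit of > 20000 nM in this assay, at which 1 of the 3 values shown sits. This position now has its first single-place reading, which is an at least 2.3-fold higher number from compound 2 to compound 3 (0.37 log units; beyond the scatter) in this assay and shows that 4-fluorophenyl and 2-fluorophenyl on the aromatic nitrogen are not interchangeable here, even though the two groups count the same under every heading computed for them. The second step, fluoro in place of hydrogen on an aromatic carbon, reads an at least 1.1-fold higher number from compound 1 to compound 3 (0.07 log units; that floor lies within the scatter) and so does not show whether that fluoro makes any difference in this assay.

From the compounds shown here alone, how far compound 3 lies past its limit remains open, so the full size of both steps is unknown. Also open, going by these compounds, is where a plain phenyl, a chloro, a methoxy or an amine on this ring would fall relative to compound 2.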